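This account rests on a few compounds, and the source may have more. Where it says the series, first, only, none or still open, it means among the compounds named here.

Measured compounds in an assay on isolated protein for inhibition of ribosomal protein S6 kinase alpha-2 (Homo sapiens), read by fluorescence, with a stated time of 20 min; a higher number here means a weaker inhibitor, a lower number a stronger inhibitor:
compound 1 `Cc1ccc(NCN2C(=O)c3ccccc3C2=O)cc1` gives 4300 nM
compound 2 `CCc1ccc(NCN2C(=O)c3ccccc3C2=O)cc1` gives 4310 nM
compound 3 `COc1ccc(NCN2C(=O)c3ccc(NC(=O)c4ccccc4)cc3C2=O)cc1` gives 2160 nM

Compound 1 and compound 2 share one core; compound 3 carries a different core, and the difference between the two cores is not broken down here. All three values sit close together, and the gaps between compound 3 and either compound 1 or compound 2 are within the scatter.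

The change from compound 1 to compound 2 is methyl in place of hydrogen on a saturated chain carbon bound to an aromatic carbon. Its step in this assay is a 1.0-fold higher number from compound 1 to compound 2 (0.00 log units; within the scatter), a flat step.

Compound 4 `CCOc1ccc(NCN2C(=O)c3ccc(NC(=O)c4ccccc4)cc3C2=O)cc1` is not yet measured. It arises from compound 3 by methyl in place of hydrogen on a saturated chain carbon bound to an oxygen on an aromatic ring. The place differs from the earlier case: there the carbon is bound to an aromatic carbon, here it is bound to an oxygen on an aromatic ring, so this is the same kind of change rather than the same one.

Because a 1.0-fold higher number from compound 1 to compound 2 (0.00 log units; within the scatter) was flat, the step from compound 3 to compound 4 in this assay is expected to be about a 1.0-fold higher number from compound 3 to compound 4 (0.01 log units; within the scatter). Compound 4 is estimated at 2200 nM, between 1000 nM and 4800 nM.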

Compound 4, half-maximal inhibitory concentration: 4580 nM
The estimate for compound 4 lay 2.1-fold (0.32 log units) below the measured number; the range from low to high includes it.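

In this assay, the change from methoxy to ethoxy gives a 2.1-fold higher number from compound 3 to compound 4 (0.33 log units; beyond the scatter), while the related change from methyl to ethyl on the other core gives a 1.0-fold higher number from compound 1 to compound 2 (0.00 log units; within the scatter). Set side by side, the two steps cannot be told apart: the same change on two cores in this assay, a 1.0-fold higher number (0.00 log units; within the scatter) from compound 1 to compound 2 and a 2.1-fold higher number (0.33 log units; beyond the scatter) from compound 3 to compound 4, 2.1-fold (0.33 log units) apart, within the scatter of two such steps. Among the compounds shown here, this gives no ground for saying that the change behaves differently on the two cores, but it does not establish that the change carries over, as there is only one pair per core and the place differs, with the carbon bound to an aromatic carbon in one pair and to an oxygen on an aromatic ring in the other.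

On these data alone, it remains open whether a longer chain on that oxygen, such as propoxy, would continue the step seen from methoxy to ethoxy, and how a hydroxyl or an amine in that place would compare. Also open, as far as these compounds go, is how methoxy and ethoxy would compare on the core of compound 1, which would test the same change at the same place on both cores.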